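The source may hold more compounds than are shown below. What is called first, only, known or untested is meant among the compounds shown, and "the series" means these compounds.

Measured compounds in a functional assay on SMMC-7721 cells (Homo sapiens) for cytotoxicity, read by MTT assay, with a stated time of 4 days; a lower number here means a stronger inhibitor, a higher number a weaker inhibitor:
Compound 1, `C=C1C(=O)[C@]23C[C@@]1(O)CC[C@H]2c1ccc(O)c(C)c1[C@@H]3Cn1cc(-c2ccc(C(F)(F)F)cc2)nn1`, gives 1440 nM.
Compound 2, `Cc1c(O)ccc2c1[C@H](Cn1cc(-c3ccc(C(F)(F)F)cc3)nn1)[C@@]13CC(=O)[C@@](C)(CC[C@@H]21)C3`, gives only a limit of the assay, > 20000 nM.
Compound 3, `C=C1C(=O)[C@]23C[C@@]1(O)CC[C@H]2c1ccc(O)c(C)c1[C@@H]3Cn1cc(-c2ccc(C)cc2)nn1`, gives 920 nM.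

Going by the values given here, the one counted change between measured compounds is methyl in place of trifluoromethyl on an aromatic carbon. It reads as a 1.6-fold lower number from compound 1 to compound 3 (0.19 log units; within the scatter), a step within the usual scatter, so the values of compound 1 and compound 3 are treated as alike. For compound 2 the assay reports (the limit of > 20000 nM in this assay, at which 1 of the 3 values shown sits), and no number. How the core of compound 2 differs from that of compound 1 is not broken down here.

Compound 4, `Cc1ccc(-c2cn(C[C@H]3c4c(ccc(O)c4C)[C@@H]4CC[C@@]5(C)C[C@]43CC5=O)nn2)cc1`, is not yet measured. It differs from compound 2 by methyl in place of trifluoromethyl on an aromatic carbon, the same change as from compound 1 to compound 3, made on a different core. Among the compounds with values here, from compound 2 to compound 4 a step of an at least 1.3-fold lower number from compound 2 to compound 4 (0.12 log units; that floor lies within the scatter) is expected, resting on the single earlier instance a 1.6-fold lower number from compound 1 to compound 3 (0.19 log units; within the scatter); since compound 2 sits at a limit, compound 4 may well return only a limit too. Compound 4 is estimated at 15000 nM, expected between 6000 nM and 40000 nM.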

Compound 4, half-maximal inhibitory concentration: > 20000 nM
Compound 4 gave a limit, no number; the forecaster's own chance of this, stated with the estimate: 60%; at least 1.3-fold (0.12 log units) between middle value and limit.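

In this assay, compound 2 and compound 4 both return a limit of the assay and no number, so the step between them cannot be read: the limit of > 20000 nM in this assay, at which 2 of the 4 values shown sit.

The compounds shown leave open whether going from 4-(trifluoromethyl)phenyl to 4-methylphenyl changes the read-out at all on the core of compound 2.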